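The compounds below may be only part of what the source reports. "The series", "measured", "known", "first", "only" and "open" are said of these compounds alone.

Compounds measured in a functional assay on DU-145 cells (Homo sapiens) for cytotoxicity, read by CCK-8 assay and cell counting, with a stated time of 2 days; a higher number here means a weaker inhibitor, a lower number a stronger inhibitor:
compound 1 `Oc1cccc(-c2cc(-c3ccc(Cl)cc3)nc(-c3cccs3)c2)c1` with 11600 nM;
compound 2 `Oc1cccc(-c2cc(-c3ccc(Cl)cc3)nc(-c3cccnc3)c2)c1` with 26800 nM;
compound 3 `Oc1cccc(-c2cc(-c3ccccc3)nc(-c3ccc(Cl)cc3)c2)c1` with 11200 nM.

Compound 3 carries the lowest number of the three in this assay, yet its nearest neighbour, compound 1, sits within the scatter of it, so no order between those two can be claimed; only compound 2 stands apart, as the step of a 2.4-fold lower number from compound 2 to compound 3 (0.38 log units; beyond the scatter) shows.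

Compound 4 `Oc1cccc(-c2cc(-c3ccncc3)nc(-c3ccc(Cl)cc3)c2)c1` departs from compound 3 in one place: pyridin-4-yl in place of phenyl on an aromatic carbon.

Within the data shown here, two measured steps bear on this change. The step of a 2.3-fold higher number from compound 1 to compound 2 (0.36 log units; beyond the scatter) and the step of a 2.4-fold lower number from compound 2 to compound 3 (0.38 log units; beyond the scatter) both show that a pyridyl group at that position, compared with thiophen-2-yl or phenyl, went with a modestly higher number, while the step of a 1.0-fold lower number from compound 1 to compound 3 (0.02 log units; within the scatter) shows phenyl and thiophen-2-yl as interchangeable. Pyridin-4-yl is a different isomer from the pyridin-3-yl of compound 2, and no compound here tests it directly, so the expectation is carried over with caution.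

Compound 4 is therefore expected to give a modestly higher number than compound 3, with a 2.0-fold higher number from compound 3 to compound 4 (0.29 log units; within the scatter), and its estimated value in this assay is 22000 nM, with a likely range from 9000 nM to 55000 nM.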

Compound 4, half-maximal inhibitory concentration: 2510 nM
Beside the measured number, compound 4's estimate is 8.8-fold (0.94 log units) above it, and the stated range ends above it.
By their numbers in this assay, from the lowest: compound 4; then compounds 3 and 1 (each within the scatter of the next); then compound 2.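

In this assay, among these compounds, the earlier compounds suggested that a pyridyl group at this position, on an aromatic carbon next to the ring nitrogen, goes with a higher number, but compound 4 shows that this does not hold for pyridyl groups as a class: moving from pyridin-3-yl to pyridin-4-yl gives an 11-fold lower number from compound 2 to compound 4 (1.03 log units; beyond the scatter), the largest step in the set. Pyridin-4-yl also stands apart from the two groups that could not be told from each other, with a 4.5-fold lower number from compound 3 to compound 4 (0.65 log units; beyond the scatter) and a 4.6-fold lower number from compound 1 to compound 4 (0.66 log units; beyond the scatter), so the same position that gave only modest differences among the earlier groups allows a clear drop in the number, and compound 4 is the only compound whose steps to all the others lie beyond the scatter. Nothing given here accounts for this difference between the two pyridyl isomers.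

Going by these compounds, it remains open whether pyridin-2-yl, an aminopyridine or a carboxylic acid at this position would follow compound 4 or compound 2. The compounds shown also leave open whether the advantage of pyridin-4-yl would persist if the 3-hydroxyphenyl or 4-chlorophenyl group were replaced, for instance by a methoxyphenyl group.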